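An amino group added to two related cores

A few compounds are considered here, and "the series" means these few. Any claim that something is new, unique, unknown or untested is made for them only; others in the source may bear on it.

Measured so far:
compound 1, `COc1ncnc2c1c(-c1cccs1)cn2[C@@H]1O[C@H](CO)[C@@H](O)[C@H]1O`: 90 nM
compound 2, `COc1nc(N)nc2c1c(-c1cccs1)cn2[C@@H]1O[C@H](CO)[C@@H](O)[C@H]1O`: > 20000 nM, a limit
compound 3, `O=c1[nH]cnc2c1c(-c1ccco1)cn2[C@@H]1O[C@H](CO)[C@@H](O)[C@H]1O`: > 20000 nM, a limit

In a functional assay on CCRF-CEM cells (Homo sapiens), read by MTT assay, with a stated time of 72 h (a higher number here means a weaker inhibitor, a lower number a stronger inhibitor), compound 1 gives 90 nM. Compound 2 is reported only as a limit, > 20000 nM. The change between them, (amino in place of hydrogen on an aromatic carbon), thus made an at least 220-fold higher number from compound 1 to compound 2 (2.34 log units; beyond the scatter). Compound 3 is likewise reported only as a limit, > 20000 nM. The difference between the core of compound 1 and the core of compound 3 is not broken down here.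

Compound 4, `Nc1nc2c(c(-c3ccco3)cn2[C@@H]2O[C@H](CO)[C@@H](O)[C@H]2O)c(=O)[nH]1`, has not been measured in this assay. Among the measured compounds shown here, its change from compound 3, (amino in place of hydrogen on an aromatic carbon), is the same kind of change as the one from compound 1 to compound 2; around the place, the entering group is meta to a methoxy group in compound 2 but meta to a group of 1 heavy atom in compound 4. Since compound 3 already sits at the limit of > 20000 nM in this assay, at which 2 of the 3 values shown sit, and the earlier step in this assay went to a higher number, compound 4 is expected to remain at that limit, an estimated 30000 nM. The expected step is a step that the limit leaves unreadable from compound 3 to compound 4.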

Compound 4, half-maximal inhibitory concentration: > 20000 nM
Compound 4 was reported as a limit (the forecaster's own chance of this, stated with the estimate: 85%); the middle value is on the limit's open side.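

In this assay compound 4 is reported only as a limit, > 20000 nM. Compound 3 is also reported only as a limit, so the step between compound 3 and compound 4 cannot be read. The compounds shown leave open whether the amino group changes the number at all on the core of compound 3.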